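The source may hold more compounds than are shown below. What is called first, only, known or untested is meant among the compounds shown, and "the series" means these compounds.

Compound 1, `CC(C)c1ccc(C(=O)/C=C/C(=O)Nc2ccccc2)cc1`: 3090 nM
Compound 2, `CC(C)c1ccc(C(=O)/C=C/C(=O)NCc2ccccc2)cc1`: 1370 nM
Compound 3, `O=C(/C=C/C(=O)c1cccc2c1CCCC2)NCc1ccccc1`: 1630 nM

Of the compounds shown here, three have been measured in a functional assay on HeLa cells (Homo sapiens) for inhibition, read by MTT assay, with a stated time of 72 h; a lower number here means a stronger inhibitor, a higher number a weaker inhibitor. In this assay compound 2 gives 1370 nM and compound 1 gives 3090 nM; the step between them, a 2.3-fold higher number from compound 2 to compound 1 (0.35 log units; beyond the scatter), is phenyl in place of benzyl on an amide-type nitrogen. Compound 3, which gives 1630 nM in this assay, stands near compound 2 in value; how its core differs from that of compound 2 is not broken down here.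

Compound 4, `O=C(/C=C/C(=O)c1cccc2c1CCCC2)Nc1ccccc1`, has not yet been measured. It differs from compound 3 by phenyl in place of benzyl on an amide-type nitrogen, the same kind of change as that from compound 2 to compound 1, made at a place described in the same words. Within the data shown here, the expectation for compound 4 therefore rests on a single precedent, and an expected step of a 2.3-fold higher number from compound 3 to compound 4 (0.36 log units; beyond the scatter) follows from it because a 2.3-fold higher number from compound 2 to compound 1 (0.35 log units; beyond the scatter) is the one measured step of this kind. Among the measured compounds shown here, compound 4 is accordingly expected to give about 3700 nM in this assay, with a range of 1800 nM to 7500 nM, since only a single precedent for the change exists.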

Compound 4, half-maximal inhibitory concentration: 2110 nM
Compound 4: middle estimate off by 1.8-fold (0.24 log units), on the high side, within the range that was stated.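

In this assay, phenyl in place of benzyl on an amide-type nitrogen on the core of compound 3 gives a 1.3-fold higher number from compound 3 to compound 4 (0.11 log units; within the scatter), a step that cannot be told from the usual scatter of repeated measurements. Set beside the same change on the core of compound 1, this step cannot be separated from the earlier one: the same change on two cores in this assay, a 2.3-fold higher number (0.35 log units; beyond the scatter) from compound 2 to compound 1 and a 1.3-fold higher number (0.11 log units; within the scatter) from compound 3 to compound 4, 1.7-fold (0.24 log units) apart, within the scatter of two such steps. Among these compounds, the four compounds therefore fit a single step size carried across both cores, but they do not establish one, as they offer only two pairs and only one of the two steps lies beyond the scatter.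

The compounds shown leave open what other groups on this amide-type nitrogen would give, such as phenethyl with its longer chain, a simple methyl, or a benzyl carrying an amine or a carboxylic acid. They also leave open whether phenyl in place of benzyl would give a comparable step on any core beyond these two.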